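This account rests on a few compounds, and the source may have more. Where it says the series, first, only, none or still open, it means among the compounds named here.

Compound 3 `COc1cc(C)cc(-c2nn(CC#N)cc2-c2ccnc(-c3ccc(N(C)C)cc3)c2)c1`: 310 nM
Compound 2 `Cc1cc(O)cc(-c2nn(CC#N)cc2-c2ccnc(-c3ccc(Oc4ccccc4)cc3)c2)c1`: 1920 nM
Compound 1 `COc1cc(C)cc(-c2c(-c3ccnc(-c4ccc(C(C)=O)cc4)c3)cnn2CC#N)c1`: 2870 nM

Of the compounds shown here, three have been tested in a functional assay on KM12 cells (Homo sapiens) for inhibition, read by sulforhodamine B assay, with a stated time of 48 h; a higher number here means a weaker inhibitor of growth, a lower number a stronger inhibitor of growth. Compound 3 gives the lowest number of the three, so it is the strongest inhibitor of growth here; compound 2 gives a higher number and compound 1 a higher one still, and both gaps lie beyond the scatter of repeated runs.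

Compound 4 `Cc1cc(O)cc(-c2nn(CC#N)cc2-c2ccnc(-c3ccc(N(C)C)cc3)c2)c1` has not yet been measured. It comes from compound 3 by a single change: hydrogen in place of methyl on an oxygen on an aromatic ring. Going by the values given here, no measured pair differs by this change alone, so the data hold no direct measure of its size. Compound 2 carries the hydroxy group and compound 1 the methoxy group, but they differ elsewhere too, so their values say nothing about this change on its own. The step is therefore expected to be modest, a 1.3-fold higher number from compound 3 to compound 4 (0.11 log units; within the scatter), with no direction that clearly rises above the scatter. Compound 4 is expected to give about 400 nM in this assay, with a range from 120 nM to 1300 nM.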

Compound 4, concentration for 50% growth inhibition: 1630 nM
Estimate against measurement, compound 4: 4.1-fold (0.61 log units) below, outside the stated range (above it).
By their numbers in this assay, from the lowest: compound 3; then compounds 4, 2 and 1 (each within the scatter of the next).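

In this assay, going by these compounds alone, methoxy to hydroxy on the 3-methoxy-5-methylphenyl group gives a 5.3-fold higher number from compound 3 to compound 4 (0.72 log units; beyond the scatter), the first direct reading of this change, and it shows that this position responds to the loss of a single methyl. With the hydroxy group held in place, dimethylamino in place of phenoxy on an aromatic carbon gives a 1.2-fold lower number from compound 2 to compound 4 (0.07 log units; within the scatter), so this swap leaves the two compounds indistinguishable in this assay, in contrast to the methoxy-to-hydroxy change. No measurement shown here explains why the methyl on the oxygen matters.

As far as these compounds go, the methoxy-to-hydroxy step rests on this one pair, so whether it holds with phenoxy or other groups in place of dimethylamino remains open. Also open, from the compounds shown here alone, is how an ethoxy group, an amino group or a fluorine atom would read at the same place.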